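A Longer Basic Side Chain on a Shared Core

The source may report more compounds than this note shows. Statements on the series, on what has been measured and on what is new or still open speak of the compounds shown alone.

Compound 1 `CN(C)CCCCn1c2c(c3ccccc31)C(=O)c1c[n+]([O-])c3ccccc3c1C2=O` gives 350 nM in a functional assay on MDA-MB-231 cells (Homo sapiens) for cytotoxicity, read by MTT assay, with a stated time of 72 h; a higher number here means a weaker inhibitor, a lower number a stronger inhibitor. Compound 2 `O=C1c2c[n+]([O-])c3ccccc3c2C(=O)c2c1c1ccccc1n2CCN1CCCC1` gives 630 nM in this assay.

Among the compounds with values here, compound 2 holds the higher of these two numbers, yet the only measured step, a 1.8-fold higher number from compound 1 to compound 2 (0.26 log units; within the scatter), lies within the scatter. Compound 3 `CCCCN1CCN(CCCCn2c3c(c4ccccc42)C(=O)c2c[n+]([O-])c4ccccc4c2C3=O)CC1` differs from compound 2 in one place: 2-(4-butylpiperazin-1-yl)ethyl in place of pyrrolidin-1-yl on a saturated chain carbon, two bonds along the chain from an aromatic nitrogen. Within the data shown here, the one step that bears on this change was within the scatter, so in this assay no step beyond the scatter is expected in either direction. Compound 3 is therefore estimated at 500 nM, with a range from 200 nM to 1500 nM. The expected step is a 1.3-fold lower number from compound 2 to compound 3 (0.10 log units; within the scatter).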

Compound 3, half-maximal inhibitory concentration: 900 nM
Compound 3: the middle estimate sits 1.8-fold (0.26 log units) below what was measured; the measured number falls inside the stated range.
By their numbers in this assay, from the lowest: compounds 1, 2 and 3 (each within the scatter of the next, the first and the last beyond it).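

In this assay, within the data shown here, 4-butylpiperazin-1-yl in place of dimethylamino, on a saturated chain carbon four bonds along the chain from an aromatic nitrogen, gives a 2.6-fold higher number from compound 1 to compound 3 (0.41 log units; beyond the scatter) as the first step beyond the scatter, though a modest one. The 2-(4-butylpiperazin-1-yl)ethyl group in place of pyrrolidin-1-yl gives a 1.4-fold higher number from compound 2 to compound 3 (0.15 log units; within the scatter) and so cannot be told apart from it here. No measurement at hand explains either step.

As far as these compounds go, whether morpholine, a primary amine or a carboxylic acid in the same place would give a larger step remains open.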